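This account rests on a few compounds, and the source may have more. Where it says the series, first, only, none or still open, it means among the compounds named here.

In an ADME assay on HEK293 cells (Homo sapiens) for cytotoxicity, read by ATP content, with a stated time of 6 h (on this read-out higher numbers stand for lower toxicity in this test and lower numbers for higher toxicity in this test), compound 1 `CCOCCNc1nc(N)nc2ccn(Cc3ccccn3)c12` gives > 24000 nM, which is a limit of the assay. Compound 2 `CC(Nc1nc(N)nc2ccn(Cc3ccccn3)c12)c1ccccn1` gives > 24000 nM, again a limit. Compound 3 `Cc1nnc(CNc2nc(N)nc3ccn(Cc4ccccn4)c23)o1` gives > 24000 nM, also a limit, so it has no number of its own. The series stands at the limit of > 24000 nM in this assay, at which 3 of the 3 values shown sit. Compound 4 `Nc1nc(NCc2ncco2)c2c(ccn2Cc2ccccn2)n1` carries 1,3-oxazol-2-yl in place of 5-methyl-1,3,4-oxadiazol-2-yl on a saturated chain carbon bound to a nitrogen on an aromatic ring. The nearest evidence is a step that the two limits leave unreadable from compound 1 to compound 3 and a step that the two limits leave unreadable from compound 2 to compound 3, and also a step that the two limits leave unreadable from compound 1 to compound 2. None of these gives a size, so no change beyond the scatter is foreseen. The expected move is a step that the limit leaves unreadable from compound 3 to compound 4. Compound 4 is estimated at 30000 nM, with an expected range of 18000 nM to 60000 nM. A further limit is the likeliest report.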

Compound 4, half-maximal cytotoxic concentration: > 24000 nM
Compound 4 gave a limit, no number; the forecaster's own chance of this, stated with the estimate: 90%; the middle value does not contradict the limit.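

Compound 4 gives only a limit, as compounds 1, 2 and 3 do, so no step among these four compounds can be read. The compounds shown leave open whether the groups changed on the shared core alter the read-out in this assay at all: the limit of > 24000 nM in this assay, at which 4 of the 4 values shown sit.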